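A few compounds are considered here, and "the series" means these few. Any claim that something is new, unique, unknown or untested is made for them only; others in the source may bear on it.

Series notes: arylsulfonamides on a three-carbon chain ending in a benzylic amine. Compound 1 `CN(CCCNS(=O)(=O)c1cc(C(F)(F)F)cc(C(F)(F)F)c1)Cc1ccccc1` gives 28000 nM in a functional assay on A2780 cells (Homo sapiens) for inhibition, read by MTT assay, with a stated time of 72 h; on this read-out higher numbers stand for weaker inhibition of growth and lower numbers for stronger inhibition of growth. Compound 2 `O=S(=O)(NCCCNCc1cccc2ccccc12)c1cc(C(F)(F)F)cc(C(F)(F)F)c1` gives 3100 nM in this assay. Compound 3 `O=S(=O)(NCCCNCc1cccc(Cl)c1)c1cc(C(F)(F)F)cc(C(F)(F)F)c1` gives 2200 nM in this assay. Compound 3 is separated from compound 1 by a large step, a 13-fold lower number from compound 1 to compound 3 (1.10 log units; beyond the scatter), and from compound 2 by a step that stays within the scatter, a 1.4-fold lower number from compound 2 to compound 3 (0.15 log units; within the scatter); the three numbers therefore split into compound 1 on one side and compounds 2 and 3 together on the other.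

Compound 4 `O=S(=O)(NCCCNCc1ccc(Cl)cc1)c1cc(C(F)(F)F)cc(C(F)(F)F)c1` differs from compound 3 only by 4-chlorophenyl in place of 3-chlorophenyl on a saturated chain carbon bound to an amine nitrogen. Among the compounds with values here, no measured step changes the position of a substituent on that ring. Within the data shown here, the only step at the same place, a 1.4-fold lower number from compound 2 to compound 3 (0.15 log units; within the scatter), swapped a whole aryl group and stayed within the scatter; the large step, a 13-fold lower number from compound 1 to compound 3 (1.10 log units; beyond the scatter), concerned the amine substitution and does not bear on a ring-position change. The expectation is therefore a step of no clear size beyond the scatter, with no direction favoured. Compound 4 is expected at 2500 nM in this assay, within 1000 nM to 6500 nM, which corresponds to an expected step of a 1.1-fold higher number from compound 3 to compound 4 (0.06 log units; within the scatter).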

Compound 4, concentration for 50% growth inhibition: 1800 nM
Estimate against measurement, compound 4: 1.4-fold (0.14 log units) above; low and high end bracket the measured number.
By their numbers in this assay, from the lowest: compounds 4, 3 and 2 (each within the scatter of the next); then compound 1.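

In this assay, within the data shown here, the first change of ring position at this place, on a saturated chain carbon bound to an amine nitrogen, gives a 1.2-fold lower number from compound 3 to compound 4 (0.09 log units; within the scatter) and leaves 3-chlorophenyl and 4-chlorophenyl unresolved, while replacing the whole aryl group gives a 1.7-fold lower number from compound 2 to compound 4 (0.24 log units; within the scatter) and likewise leaves 4-chlorophenyl and naphthalen-1-yl unresolved. The large gap seen with the 3-chlorobenzyl compound recurs with the 4-chlorobenzyl group, as a 16-fold lower number from compound 1 to compound 4 (1.19 log units; beyond the scatter), so it does not depend on which of these two chlorophenyl groups is present. Nothing measured here explains why these aryl groups read alike.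

Still open, from the compounds shown here alone, is whether the methyl on the amine or the ring chlorine accounts for the large step, since both differ across it. Also open, going by these compounds, is how a methoxy group or nitrile on this ring, or a longer chain, would read.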